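The source may hold more compounds than are shown below. What is called first, only, known or untested is meant among the compounds shown, and "the series" means these compounds.

Of the compounds shown here, three built on one shared core have so far been read in a toxicity assay on HeLa cells (Homo sapiens) for cytotoxicity, read by colorimetric assay, with a stated time of 72 h; on this read-out higher numbers stand for lower toxicity in this test and lower numbers for higher toxicity in this test. Here compound 1 `O=c1nc(N2CC[C@@](O)(COc3ccc(F)cc3)[C@H](O)C2)sc2c([N+](=O)[O-])cc(C(F)(F)F)cc12` gives 18400 nM and compound 2 `O=c1nc(N2Cc3ccccc3[C@H](CO)C2)sc2c([N+](=O)[O-])cc(C(F)(F)F)cc12` gives 86400 nM as measured numbers. Compound 3 `CC(=O)c1ccc(N2CCN(c3nc(=O)c4cc(C(F)(F)F)cc([N+](=O)[O-])c4s3)CC2)cc1`, which carries 4-acetylphenyl on an amine nitrogen in a ring, has no number at all, only the limit of > 105000 nM in this test.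

Compound 4 `O=C(CN1CCN(c2nc(=O)c3cc(C(F)(F)F)cc([N+](=O)[O-])c3s2)CC1)Nc1ccccc1` has (phenylcarbamoyl)methyl in place of 4-acetylphenyl at that same amine nitrogen (phenylcarbamoyl)methyl in place of 4-acetylphenyl on an amine nitrogen in a ring and is still unmeasured. With compound 3 known only as a limit, any step from it can only be approximate. Within the data shown here, the sole numbers to lean on are compound 2 at 86400 nM and compound 1 at 18400 nM with other groups on the shared core, so a modest move toward lower numbers, meaning higher toxicity, is expected rather than a large one. The expected change is an at least 1.5-fold lower number from compound 3 to compound 4 (0.17 log units; that floor lies within the scatter) by this estimate. For compound 4 the estimated value is 70000 nM with an expected range of 22000 nM to 130000 nM on this read-out.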

Compound 4, half-maximal cytotoxic concentration: > 101000 nM
Compound 4: only a limit was reported (the forecaster's own chance of this, stated with the estimate: 40%); at least 1.4-fold (0.15 log units) between middle value and limit.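

In this assay compound 3 gives only a limit, > 105000 nM. Compound 4 also gives only a limit, > 101000 nM. Among these compounds, with two limits, no step between these two compounds can be read. The compounds shown leave open how far replacing 4-acetylphenyl with (phenylcarbamoyl)methyl shifts this read-out, if at all.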